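Swapping Propyl for Acetoxy on the Ester Chain

A few compounds are considered here, and "the series" means these few. Any claim that something is new, unique, unknown or untested is made for them only; others in the source may bear on it.

In an ADME assay on HepG2 2.2.15 cells (Homo sapiens) for cytotoxicity (a higher number here means that more compound is tolerated, a lower number that less compound is tolerated), compound 1 `O=CCc1c(-c2ccccc2Cl)c2cc(Cl)ccc2[nH]c1=O` gives 120000 nM, compound 2 `CC(=O)OCCc1c(-c2ccccc2Cl)c2cc(Cl)ccc2[nH]c1=O` gives 27000 nM, and compound 3 `CCCCC(=O)OCCc1c(-c2ccccc2Cl)c2cc(Cl)ccc2[nH]c1=O` gives 200000 nM. Compound 3 thus stands level with compound 1, as a 1.7-fold higher number from compound 1 to compound 3 (0.22 log units; within the scatter) shows, and clear of compound 2.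

Compound 4 `CC(=O)OCC(=O)OCCc1c(-c2ccccc2Cl)c2cc(Cl)ccc2[nH]c1=O` differs from compound 3 by acetoxy in place of propyl on a saturated chain carbon bound to a carbonyl carbon. The closest evidence is the change at that same place, propyl in place of hydrogen, which gave a 7.4-fold higher number from compound 2 to compound 3 (0.87 log units; beyond the scatter). The step of a 4.4-fold lower number from compound 1 to compound 2 (0.65 log units; beyond the scatter) shows that the number can also fall in this small set. Going by the values given here, no measured compound carries acetoxy at that place, so the size remains uncertain. With the propyl removed, part of the rise seen in a 7.4-fold higher number from compound 2 to compound 3 (0.87 log units; beyond the scatter) may be lost, and a modest fall in this assay is expected. The expected change is a 2.9-fold lower number from compound 3 to compound 4 (0.46 log units; beyond the scatter). For compound 4 the estimate is 70000 nM, with an expected range from 22000 nM to 200000 nM.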

Compound 4, half-maximal cytotoxic concentration: 100000 nM
Beside the measured number, compound 4's estimate is 1.4-fold (0.15 log units) below it; measured number inside the range.
By their numbers in this assay, from the lowest: compound 2; then compounds 4, 1 and 3 (each within the scatter of the next).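

In this assay, the rise over hydrogen on the saturated chain carbon bound to a carbonyl carbon turns out not to be particular to propyl: acetoxy in place of hydrogen gives a 3.7-fold higher number from compound 2 to compound 4 (0.57 log units; beyond the scatter), while acetoxy in place of propyl gives a 2.0-fold lower number from compound 3 to compound 4 (0.30 log units; within the scatter), so the two groups cannot be told apart here. The longer ester side chain of compound 4 also stays level with the formyl-bearing chain, with a 1.2-fold lower number from compound 1 to compound 4 (0.08 log units; within the scatter). No measurement here explains why these two different groups give numbers within the scatter of each other.

The compounds shown leave open whether an amine, a carboxylic acid or a longer chain at this place would also hold the number up. They also leave open whether the low number of compound 2 stands alone among the small esters, as a formyl or hydroxyl group at this place might show.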